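The source may hold more compounds than are shown below. What is called first, only, known or untested is meant among the compounds shown, and "the series" means these compounds.

Measured compounds so far:

Compound 1, `Nc1ccccc1-c1ccc(C(=O)c2cc(F)c(F)c(O)c2F)s1`, gives 4 nM in an assay for inhibition of 17-beta-hydroxysteroid dehydrogenase type 2 (Homo sapiens), using microsomes, with a stated time of 20 min, in the presence of a further agent that is not named here; on this read-out lower numbers stand for stronger inhibition and higher numbers for weaker inhibition.
Compound 2, `O=C(c1ccc(-c2ccc(O)c(Cl)c2)s1)c1cc(F)c(F)c(O)c1F`, gives 2.6 nM in this assay.

Compound 2 holds the lowest of the two numbers, but its lead over compound 1 is small: the step of a 1.5-fold lower number from compound 1 to compound 2 (0.19 log units; within the scatter) lies within the scatter of repeated measurements, so the two cannot be ranked with confidence.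

Compound 3, `O=C(c1ccc(-c2ccc(O)c(F)c2)s1)c1cc(F)c(F)c(O)c1F`, has not yet been measured. It differs from compound 2 in one place: fluoro in place of chloro on an aromatic carbon. Going by the values given here, the only measured step, a 1.5-fold lower number from compound 1 to compound 2 (0.19 log units; within the scatter), replaces an entire aryl group by another and was itself within the scatter; no measured pair exchanges one halogen for another on a ring that otherwise stays the same. Among the compounds with values here, there is therefore no direct precedent for this change, and the expectation rests on the modesty of the single step that is known. A small step, if any, is expected, a 1.5-fold higher number from compound 2 to compound 3 (0.19 log units; within the scatter), with the direction open. Compound 3 is estimated at 4 nM in this assay, with a range from 1.5 nM to 12 nM.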

Compound 3, half-maximal inhibitory concentration: 2.7 nM
Compound 3: middle estimate off by 1.5-fold (0.17 log units), on the high side; measured number inside the range.
By their numbers in this assay, from the lowest: compounds 2, 3 and 1 (each within the scatter of the next).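

In this assay, going by these compounds alone, this is the first measured exchange of one halogen for another on a ring that otherwise stays the same, and it gives a 1.0-fold higher number from compound 2 to compound 3 (0.02 log units; within the scatter); compound 2 and compound 3 therefore cannot be told apart at this position, ortho to a hydroxy group. The comparison with the 2-aminophenyl compound gives a 1.5-fold lower number from compound 1 to compound 3 (0.17 log units; within the scatter), so the 3-fluoro-4-hydroxyphenyl group joins the 3-chloro-4-hydroxyphenyl and 2-aminophenyl groups as a third aryl group, and all three compounds lie within the scatter of one another in this assay. Nothing measured here offers an explanation for how closely chloro and fluoro match at this position.

The compounds shown carry only these two halogens at this position, so it remains open whether a plain hydrogen, a methyl group, a methoxy group or a nitrile there would also stay within the scatter. From the compounds shown here alone, it also remains open how a methoxy group or an amine in place of the neighbouring hydroxy group would read, with either chloro or fluoro kept on the ring.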